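Trifluoromethoxy to trifluoromethyl in an antiproliferative series

This account rests on a few compounds, and the source may have more. Where it says the series, first, only, none or still open, it means among the compounds named here.

- compound 1 `O=C(CCc1cccc2c1B(O)OC2)Nc1cccc(-c2ccc(F)cc2)c1` gives 93 nM
- compound 2 `O=C(CCc1cccc2c1B(O)OC2)Nc1cccc(-c2cccc(OC(F)(F)F)c2)c1` gives 460 nM

Among the compounds with values here, in a functional assay on SK-OV-3 cells (Homo sapiens) for antiproliferative activity, read by MTT assay, with a stated time of 72 h (on this read-out lower numbers stand for stronger inhibition and higher numbers for weaker inhibition), compound 2 (460 nM) holds the higher of the two numbers so far, and its gap to compound 1 (93 nM) lies beyond the scatter. The next entry is compound 3 `O=C(CCc1cccc2c1B(O)OC2)Nc1cccc(-c2cccc(C(F)(F)F)c2)c1`, which has not yet been measured. Relative to compound 2, trifluoromethyl stands in place of trifluoromethoxy on an aromatic carbon, meta to a large group (trifluoromethyl in place of trifluoromethoxy on an aromatic carbon). Within the data shown here, no pair of measured compounds shows this exchange, so the series offers no direct precedent for it. In this assay no change beyond the scatter is expected, with only a slight lean towards a lower number. The expected step of a 1.3-fold lower number from compound 2 to compound 3 (0.12 log units; within the scatter) is an estimate that carries real uncertainty. The range is kept wide, as the two measured compounds already differ beyond the scatter, with compound 1 at 93 nM and compound 2 at 460 nM. The expected value for compound 3 is 350 nM (estimated range 120 nM to 1000 nM).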

Compound 3, half-maximal inhibitory concentration: 390 nM
Compound 3: the middle estimate sits 1.1-fold (0.05 log units) below what was measured; the range from low to high includes it.
By their numbers in this assay, from the lowest: compound 1; then compounds 3 and 2 (each within the scatter of the next).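

In this assay, trifluoromethyl in place of trifluoromethoxy on an aromatic carbon, meta to a large group, gives a 1.2-fold lower number from compound 2 to compound 3 (0.07 log units; within the scatter), so at this position the oxygen of trifluoromethoxy can go without any readable separation between the two compounds. 3-(Trifluoromethyl)phenyl in place of 4-fluorophenyl gives a 4.2-fold higher number from compound 1 to compound 3 (0.62 log units; beyond the scatter), so the gap to compound 1 that compound 2 alone had shown now appears with a second fluorinated group, and both compounds carrying such a group at this position stand apart from compound 1 by more than the scatter. Nothing on hand offers an explanation for either step.

The step from compound 1 changes both the group and its place on the aromatic ring, so the compounds shown do not separate which of the two accounts for the gap. Also open, going by these compounds, is how the series answers to a group of another kind on this same aromatic carbon, such as an amine or a carboxylic acid, in place of trifluoromethyl.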